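Replacing the Ester Oxygen by an Amide Nitrogen

The source may report more compounds than this note shows. Statements on the series, on what has been measured and on what is new or still open speak of the compounds shown alone.

Among the compounds with values here, compound 1 `CCOC(=O)C(C)(C)C(c1ccc(Nc2ccc3ccccc3c2)cc1)n1ccnc1` gives 0.35 nM in an assay on isolated protein for inhibition of cytochrome P450 26A1 (Homo sapiens), read by scintillation counting (on this read-out higher numbers stand for weaker inhibition and lower numbers for stronger inhibition), the lowest of the two numbers measured so far; compound 2 `CCCCOC(=O)C(C)(C)C(c1ccc(Nc2ccc3ccccc3c2)cc1)n1ccnc1` gives 200 nM. Compound 3 `CNC(=O)C(C)(C)C(c1ccc(Nc2ccc3ccccc3c2)cc1)n1ccnc1` differs from compound 1 by methylamino in place of ethoxy on a carbonyl carbon. Within the data shown here, no measured step changes the carbonyl carbon in this way, and the one step measured, a 570-fold higher number from compound 1 to compound 2 (2.76 log units; beyond the scatter), shows only that alterations at this end of the molecule can shift the number strongly. A step towards a higher number, of moderate size, is therefore expected a 14-fold higher number from compound 1 to compound 3 (1.15 log units; beyond the scatter). Compound 3 is estimated at 5 nM, within 0.5 nM to 50 nM.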

Compound 3, half-maximal inhibitory concentration: 12 nM
Compound 3: the middle estimate sits 2.4-fold (0.38 log units) below what was measured; the measured number falls inside the stated range.
By their numbers in this assay, from the lowest: compound 1; then compound 3; then compound 2.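

Putting methylamino in place of ethoxy on the carbonyl carbon gives a 34-fold higher number from compound 1 to compound 3 (1.54 log units; beyond the scatter), so this position responds strongly to a change of ester to amide. Methylamino in place of butoxy gives a 17-fold lower number from compound 2 to compound 3 (1.22 log units; beyond the scatter), so having an ester here does not by itself give the lower number; the outcome depends on which ester it is. Nothing available explains either step. The compounds shown leave open whether the nitrogen or the chain on it drives these steps. Ethylamino, dimethylamino or a carboxylic acid on this carbonyl carbon would help separate the two.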